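A few compounds are considered here, and "the series" means these few. Any claim that something is new, unique, unknown or untested is made for them only; others in the source may bear on it.

Measured so far:
compound 1 `Nc1ncnc2c1ncn2C[C@@H]1C[C@H](O)c2ccccc21` — > 200000 nM
compound 2 `Nc1nc(Cl)c2nnn([C@H]3CCCC[C@H]3CO)c2n1` — 95500 nM

In an ADME assay on L1210/0 cells (Mus musculus) for cytotoxicity, with a stated time of 48 h (a higher number here means a weaker inhibitor, a lower number a stronger inhibitor), compound 1 gives only a limit of the assay, > 200000 nM, which is the limit of > 200000 nM in this assay, at which 1 of the 2 values shown sits. Compound 2 gives 95500 nM in this assay. Among the measured compounds shown here, no step between the two measured compounds can be stated, as they differ in more than one place. Compound 3 `COc1ncnc2c1ncn2C[C@@H]1C[C@H](O)c2ccccc21` differs from compound 1 by methoxy in place of amino on an aromatic carbon. For this change in this assay no step beyond the usual scatter is expected, and the read-out is expected to come back as a limit again. The estimate for compound 3 is 200000 nM, in the range 60000 nM to 600000 nM, meaning an expected step of a number no higher from compound 1 to compound 3 (the limit leaves the size open).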

Compound 3, half-maximal inhibitory concentration: > 200000 nM
Compound 3 gave a limit, no number; the forecaster's own chance of this, stated with the estimate: 75%; the middle value sits exactly at the limit.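

In this assay no step can be read between compound 1 and compound 3, because both give only a limit of the assay: the limit of > 200000 nM in this assay, at which 2 of the 3 values shown sit. On these data alone, whether methoxy in place of amino shifts the read-out at all stays open.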